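This account rests on a few compounds, and the source may have more. Where it says the series, first, only, none or still open, it means among the compounds named here.

Compound 1 `O=C(NCc1ccc(S(=O)(=O)N2CCOCC2)cc1)c1cc2ccncc2o1` gives 32 nM in an assay for inhibition of Nicotinamide phosphoribosyltransferase (Homo sapiens), with stated times of 15 min and 30 min (on this read-out lower numbers stand for stronger inhibition and higher numbers for weaker inhibition), the lowest of the two numbers in the set. Compound 2 `O=C(NCc1ccc(S(=O)(=O)N2CCOCC2)cc1)c1cc2cnccc2[nH]1` gives 88 nM in this assay, and a 2.8-fold higher number from compound 1 to compound 2 (0.44 log units; beyond the scatter) marks the exchange on the carbonyl carbon. Compound 3 `CC(C)N1CCC([S+]([O-])c2ccc(CNC(=O)c3cc4ccncc4o3)cc2)CC1` has several entries in this assay, > 2000 nM; 26 nM; 60 nM (3 entries), as shown in the several entries of compound 3 in this assay, > 2000 nM; 26 nM; 60 nM (3 entries). Compound 4 `Cc1ccc(S(=O)(=O)c2ccc(CNC(=O)c3cc4ccncc4o3)cc2)cn1` differs from compound 1 by 6-methylpyridin-3-yl in place of morpholin-4-yl on a sulfonyl sulfur. Among the compounds with values here, no measured step addresses the group on the sulfonyl sulfur: the step from compound 1 to compound 2 alters the core, and compound 3 carries a different sulfur linkage together with a different ring, its numbered entries sitting near those of compound 1. The available steps give no pointer to a change in either direction for compound 4, and the expected step of a 1.3-fold higher number from compound 1 to compound 4 (0.10 log units; within the scatter) is none beyond the scatter. Compound 4 is estimated at 40 nM, with a range of 10 nM to 160 nM.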

Compound 4, half-maximal inhibitory concentration: 11 nM
Beside the measured number, compound 4's estimate is 3.6-fold (0.56 log units) above it, and the stated range covers the measured number.
By their numbers in this assay, from the lowest: compound 4; then compound 1; then compound 2.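

On the sulfonyl sulfur, the series responds in this assay to replacing the ring: with 6-methylpyridin-3-yl in place of morpholin-4-yl, the result is a 2.9-fold lower number from compound 1 to compound 4 (0.46 log units; beyond the scatter). Within the data shown here, the earlier step altered the core, so this is the first single change read at this position, and it shows that morpholin-4-yl is not required there: a six-membered aromatic ring is accepted on the core of compound 1. No measurement shown bears on the origin of this step.

Going by these compounds, it remains open whether the step depends on the ring nitrogen or on the methyl group, which phenyl or unsubstituted pyridin-3-yl on the sulfonyl sulfur could separate. Also open, on these data alone, are the effect of a piperidin-1-yl group or a carboxylic acid on the pyridine ring at this position, and whether the step carries over to the core of compound 2.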